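Chloro for pyridin-3-yl at two positions of the shared core

The source may report more compounds than this note shows. Statements on the series, on what has been measured and on what is new or still open speak of the compounds shown alone.

Compound 1 `N#Cc1ccc(NC(=O)c2ccc(Cl)cc2O)cc1`, compound 2 `N#Cc1ccc(NC(=O)c2ccc(-c3cccnc3)cc2O)cc1` and compound 3 `N#Cc1ccc(NC(=O)c2cc(-c3cccnc3)ccc2O)cc1` have been measured in a functional assay on KG-1 cells (Homo sapiens) for cytotoxicity, read by luminescence and CellTiter-Glo, with a stated time of 3 days; a lower number here means a stronger inhibitor, a higher number a weaker inhibitor. Compound 1 gives 1920 nM, compound 2 gives 7940 nM and compound 3 gives 8330 nM; the values of compound 2 and compound 3 lie within the scatter of each other. Compound 1 and compound 2 differ in one place, (chloro in place of pyridin-3-yl on an aromatic carbon), and that step gave a 4.1-fold lower number from compound 2 to compound 1 (0.62 log units; beyond the scatter). Compound 3 and compound 2 are built from the same atoms joined differently; the difference between their two cores is not broken down here.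

Compound 4 `N#Cc1ccc(NC(=O)c2cc(Cl)ccc2O)cc1` has not yet been measured. It differs from compound 3 by chloro in place of pyridin-3-yl on an aromatic carbon. This is the same kind of change as that between compound 2 and compound 1, not the same one: in compound 1 the chloro stands meta to a hydroxy group and para to a large group, while in compound 4 it stands meta to a large group and para to a hydroxy group.

For compound 4 the step expected in this assay is a 3.3-fold lower number from compound 3 to compound 4 (0.52 log units; beyond the scatter), because the same kind of change made the step of a 4.1-fold lower number from compound 2 to compound 1 (0.62 log units; beyond the scatter); the different place widens the range. Compound 4 is thus estimated at 2500 nM, between 900 nM and 7000 nM.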

Compound 4, half-maximal inhibitory concentration: 1860 nM
For compound 4 the middle estimate is 1.3-fold (0.13 log units) above the measured one, and the stated range covers the measured number.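

In this assay the exchange of pyridin-3-yl for chloro gave a 4.5-fold lower number from compound 3 to compound 4 (0.65 log units; beyond the scatter), with the chloro on an aromatic carbon meta to a large group and para to a hydroxy group. Set beside the earlier step on the other core, the change carried over with no difference in size beyond the scatter: the same change on two cores in this assay, a 4.1-fold lower number (0.62 log units; beyond the scatter) from compound 2 to compound 1 and a 4.5-fold lower number (0.65 log units; beyond the scatter) from compound 3 to compound 4, 1.1-fold (0.03 log units) apart, within the scatter of two such steps. Among these compounds, this shows only that the step held for these two pairs in this assay; it gives no rule for the wider series, does not show that the step would hold on a further core, and does not explain why the number drops.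

On these data alone, only chloro and pyridin-3-yl have been compared at these two places, so it remains open whether an amine, a carboxylic acid or a longer chain there would give a step of similar size. The compounds shown also leave open what happens when the nitrile or the hydroxy group is replaced, for example by a methoxy group.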